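A Fluorinated Group Replaces Ethoxy on the Shared Core

This account rests on a few compounds, and the source may have more. Where it says the series, first, only, none or still open, it means among the compounds named here.

Three compounds share one core and differ only in the group on one aromatic carbon. In a functional assay on Hep 3B2 cells (Homo sapiens) for antiproliferative activity, read by MTT assay, with a stated time of 24 h, tested at 0.02 ug/mL (a lower number here means a weaker effect, a higher number a stronger effect of the compound at the concentration tested), compound 1 `Cc1ccc2nc(C(=O)Nc3c(F)cc(-c4cccc(F)c4)cc3F)c(C)c(O)c2c1` gives 0.98%. Compound 2 `Cc1c(C(=O)Nc2c(F)cc(-c3cccc(F)c3)cc2F)nc2ccc(F)cc2c1O` gives 0.35%. Compound 3 `CCOc1ccc2nc(C(=O)Nc3c(F)cc(-c4cccc(F)c4)cc3F)c(C)c(O)c2c1` gives -0.32%, standing nearest to compound 2 and furthest from compound 1, with all three numbers within the scatter of one another. Compound 4 `Cc1c(C(=O)Nc2c(F)cc(-c3cccc(F)c3)cc2F)nc2ccc(C(F)(F)F)cc2c1O` differs from compound 3 by trifluoromethyl in place of ethoxy on an aromatic carbon. The exchanges made at this same carbon, a number 1.3 percentage points lower from compound 1 to compound 3 (within the scatter) and a number 0.7 percentage points lower from compound 2 to compound 3 (within the scatter), both stayed within the scatter, as did a number 0.6 percentage points lower from compound 1 to compound 2 (within the scatter). A further exchange there is therefore expected to give no step beyond the scatter, namely a number 0.6 percentage points higher from compound 3 to compound 4 (within the scatter). Compound 4 is expected to give 0.3%, within -6% to 7%.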

Compound 4, a percentage reported as inhibition, at one concentration (the size of the read-out at that concentration, not a potency): 0.06%
Compound 4: the middle estimate sits 0.2 percentage points above what was measured; low and high end bracket the measured number.
By their numbers in this assay, from the lowest: compounds 3, 4, 2 and 1 (each within the scatter of the next).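

At this aromatic carbon, trifluoromethyl makes no difference that can be read in this assay when set against ethoxy (a number 0.4 percentage points higher from compound 3 to compound 4 (within the scatter)), against fluoro (a number 0.3 percentage points lower from compound 2 to compound 4 (within the scatter)) or against methyl (a number 0.9 percentage points lower from compound 1 to compound 4 (within the scatter)). Four groups at this carbon now give numbers all within the scatter of one another, so the read-out at the single concentration tested does not separate them. No data shown here offer a reason for this.

Going by these compounds, whether another kind of group at this carbon, such as an amine or a carboxylic acid, would move the number beyond the scatter stays open. So does whether these four compounds would differ at higher concentrations.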